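The source may report more compounds than this note shows. Statements on the series, on what has been measured and on what is new or still open speak of the compounds shown alone.

Measured so far in an ADME assay on L02 cells (Homo sapiens) for inhibition, read by CCK-8 assay, with a stated time of 48 h; a higher number here means a weaker inhibitor of growth, a lower number a stronger inhibitor of growth:
compound 1 `COc1ccc(CNc2nc(Nc3ccc(N4CCN(C)CC4)cn3)ncc2Cl)cc1` — 12900 nM
compound 2 `COc1ccccc1CNc1nc(Nc2ccc(N3CCN(C)CC3)cn2)ncc1Cl` — 25500 nM

For the measured compounds named here, compound 2 holds the higher of the two numbers, but the only step, a 2.0-fold higher number from compound 1 to compound 2 (0.30 log units; within the scatter), lies within the scatter, so the two compounds are not separated. Compound 3 `CC(C)c1ccc(Nc2nc(Nc3ccc(N4CCN(C)CC4)cn3)ncc2Cl)cc1` differs from compound 2 by 4-isopropylphenyl in place of 2-methoxybenzyl on a nitrogen on an aromatic ring. Going by the values given here, no measured step touches this kind of change; the one step on hand moved a methoxy around the benzyl ring and stayed within the scatter. With nothing pointing either way, the step of a 1.3-fold lower number from compound 2 to compound 3 (0.11 log units; within the scatter) is expected to stay near the scatter, and compound 3 is estimated at 20000 nM, within 6000 nM to 65000 nM.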

Compound 3, concentration for 50% growth inhibition: 13700 nM
Compound 3: the middle estimate sits 1.5-fold (0.16 log units) above what was measured; the measured number falls inside the stated range.
By their numbers in this assay, from the lowest: compounds 1, 3 and 2 (each within the scatter of the next).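

In this assay 4-isopropylphenyl in place of 2-methoxybenzyl on this nitrogen gives a 1.9-fold lower number from compound 2 to compound 3 (0.27 log units; within the scatter) and, in place of 4-methoxybenzyl, gives a 1.1-fold higher number from compound 1 to compound 3 (0.03 log units; within the scatter) on the same nitrogen. Exchanging the whole group, not just moving a methoxy around the benzyl ring, therefore still leaves the three compounds unseparated. No supporting data bear on this result.

On these data alone, whether a carboxylic acid or an amine on the phenyl ring, or a longer chain on the nitrogen, would give a step beyond the scatter remains open.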